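Series notes: benzyl substituent swap and its expected effect

The source may hold more compounds than are shown below. What is called first, only, known or untested is meant among the compounds shown, and "the series" means these compounds.

Measured so far:
- compound 1 `N#Cc1c(Nc2ccccc2F)nc(SCc2cn(Cc3ccccc3Cl)nn2)nc1-c1ccccc1`: 23000 nM
- compound 2 `Cc1ccc(Cn2cc(CSc3nc(Nc4ccccc4F)c(C#N)c(-c4ccccc4)n3)nn2)cc1`: > 64000 nM
- compound 3 `Cc1ccc(Cn2cc(CSc3nc(Nc4ccc(C)cc4)c(C#N)c(-c4ccccc4)n3)nn2)cc1`: 55700 nM

The value of compound 2 in a functional assay on ECa-109 cells (Homo sapiens) for inhibition, read by MTT assay, with a stated time of 72 h (on this read-out lower numbers stand for stronger inhibition and higher numbers for weaker inhibition), is a limit of the assay, not a number (the limit of > 64000 nM in this assay, at which 1 of the 3 values shown sits). Compound 2 and compound 1 differ in one place: 2-chlorophenyl in place of 4-methylphenyl on a saturated chain carbon bound to an aromatic nitrogen. Measured, this change gave an at least 2.7-fold lower number from compound 2 to compound 1 (0.44 log units; beyond the scatter). The cores of compound 2 and compound 3 differ as follows: 4-methylphenyl in place of 2-fluorophenyl on a nitrogen on an aromatic ring; this gave an at least 1.1-fold lower number from compound 2 to compound 3 (0.06 log units; that floor lies within the scatter). Compound 4 `Cc1ccc(Nc2nc(SCc3cn(Cc4ccccc4Cl)nn3)nc(-c3ccccc3)c2C#N)cc1` is not yet measured. It differs from compound 3 by 2-chlorophenyl in place of 4-methylphenyl on a saturated chain carbon bound to an aromatic nitrogen, the same change as between compound 2 and compound 1, at the same place. Because the earlier instance gave an at least 2.7-fold lower number from compound 2 to compound 1 (0.44 log units; beyond the scatter), a lowering of similar size is expected here. Compound 4 is estimated at 20000 nM, with a range from 8000 nM to 50000 nM. The expected step is a 2.8-fold lower number from compound 3 to compound 4 (0.44 log units; beyond the scatter).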

Compound 4, half-maximal inhibitory concentration: > 64000 nM
Compound 4 was reported as a limit; the forecaster's own chance of this, stated with the estimate: 10%; middle value at least 3.2-fold (0.50 log units) from the limit.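

In this assay compound 4 gives > 64000 nM, which is a limit of the assay and not a number. The change from 4-methylbenzyl to 2-chlorobenzyl does not carry over from the core of compound 2 to the core of compound 3, where it gives an at least 1.1-fold higher number from compound 3 to compound 4 (0.06 log units; that floor lies within the scatter): the same change on two cores in this assay, an at least 2.7-fold lower number (0.44 log units; beyond the scatter) from compound 2 to compound 1 and an at least 1.1-fold higher number (0.06 log units; that floor lies within the scatter) from compound 3 to compound 4, at least 3.1-fold (0.50 log units) apart, beyond the scatter of two such steps. The swap of 2-fluorophenyl for 4-methylphenyl on a nitrogen on an aromatic ring gives an at least 2.7-fold higher number from compound 1 to compound 4 (0.44 log units; beyond the scatter), and with compound 2 and compound 4 both at a limit, the gap between steps is shown but the true size of each step is not: the same change on two cores in this assay, an at least 1.1-fold lower number (0.06 log units; that floor lies within the scatter) from compound 2 to compound 3 and an at least 2.7-fold higher number (0.44 log units; beyond the scatter) from compound 1 to compound 4, at least 3.1-fold (0.50 log units) apart, beyond the scatter of two such steps.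

Still open, going by these compounds, is whether a benzyl group carrying an amine or a carboxylic acid would give a measurable number on either core. The same applies to a longer chain in place of the benzyl group.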